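This account rests on a few compounds, and the source may have more. Where it says the series, first, only, none or still open, it means among the compounds named here.

Of the compounds shown here, three sharing one core have been measured in a functional assay, tested at 200 ug/mL; a higher number here means a stronger effect of the compound at the concentration tested, a lower number a weaker effect. Compound 1 `N#CC1=C(N)OC(c2c[nH]c3ccccc23)=C(C#N)C1c1ccc2ccccc2c1` was reported in this assay as "not active" (no number reported), with no number attached. Compound 2 `CN(C)c1ccc(C2C(C#N)=C(N)OC(c3c[nH]c4ccccc34)=C2C#N)cc1` gives 20.5% in this assay, and compound 3 `N#CC1=C(N)OC(c2c[nH]c3ccccc23)=C(C#N)C1c1ccccc1Cl` gives 14.5%. For the measured compounds named here, the only step that can be read between these structures is a number 6 percentage points lower from compound 2 to compound 3 (within the scatter), so the two numbers that exist sit close together, and compound 3 stands alongside compound 2 rather than apart from it.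

Compound 4 `N#CC1=C(N)OC(c2c[nH]c3ccccc23)=C(C#N)C1c1ccc(F)cc1` has not yet been measured. It differs from compound 3 by 4-fluorophenyl in place of 2-chlorophenyl on a saturated ring carbon. Going by the values given here, the one step bearing on this change is the swap of one aryl group for another on the same saturated ring carbon, a number 6 percentage points lower from compound 2 to compound 3 (within the scatter), which stayed inside the scatter. On that basis the change from compound 3 to compound 4 is expected to give no step beyond the scatter, a number 0.5 percentage points lower from compound 3 to compound 4 (within the scatter). Compound 4 is therefore estimated at 14% in this assay, within a range of 0% to 30%, with some chance that, like compound 1, only an inactive result is reported.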

Compound 4, a percentage reported as activity, at one concentration (the size of the read-out at that concentration, not a potency): 22.4%
Estimate against measurement, compound 4: 8.4 percentage points below, and the stated range covers the measured number.
By their numbers in this assay, from the lowest: compounds 3, 2 and 4 (each within the scatter of the next).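

Swapping 2-chlorophenyl for 4-fluorophenyl on the saturated ring carbon gives a number 7.9 percentage points higher from compound 3 to compound 4 (within the scatter), and fluoro in place of dimethylamino on the aromatic carbon gives a number 1.9 percentage points higher from compound 2 to compound 4 (within the scatter). In this assay, the phenyl groups at this position therefore show no separable difference across compounds 2, 3 and 4, whether the substituent is dimethylamino, chloro or fluoro, although compound 1, reported as "not active" (no number reported), stands outside this pattern. Nothing available explains this result.

The step from compound 3 changes both the halogen and the place it occupies on the phenyl ring, so the two changes cannot be told apart. The compounds shown also leave open what a carboxylic acid or a longer chain on that phenyl ring would give at this concentration.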